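The source may report more compounds than this note shows. Statements on the series, on what has been measured and on what is new or still open speak of the compounds shown alone.

In a functional assay on HeLa cells (Homo sapiens) for inhibition, read by MTT assay, with a stated time of 72 h (on this read-out lower numbers stand for stronger inhibition and higher numbers for weaker inhibition), compound 1 `CC(C)(C)Oc1ccc(-c2nnc(SCCCN3CCN(c4nc5ccccc5o4)CC3)o2)cc1` gives 269000 nM, compound 2 `Oc1ccc(-c2nnc(SCCCN3CCN(c4nc5ccccc5o4)CC3)o2)cc1` gives 99500 nM, and compound 3 `O=C(NCc1nnc(SCCCN2CCN(c3nc4ccccc4o3)CC2)o1)c1ccccc1` gives 63900 nM. Compound 3 stands apart from compound 1 by a 4.2-fold lower number from compound 1 to compound 3 (0.62 log units; beyond the scatter), while its gap to compound 2, a 1.6-fold lower number from compound 2 to compound 3 (0.19 log units; within the scatter), lies within the scatter, so those two cannot be ranked. Compound 4 `O=C(NCc1nnc(SCCCN2CCN(c3nc4ccccc4s3)CC2)o1)c1ccccc1` differs from compound 3 by 1,3-benzothiazol-2-yl in place of 1,3-benzoxazol-2-yl on an amine nitrogen in a ring. The measured steps, a 2.7-fold lower number from compound 1 to compound 2 (0.43 log units; beyond the scatter) among them, all concern the group at the other end of the shared core, so nothing measured bears directly on this exchange. The expected step is therefore a 1.1-fold lower number from compound 3 to compound 4 (0.03 log units; within the scatter), nothing beyond the scatter. For compound 4 the estimate is 60000 nM, within the range 20000 nM to 180000 nM.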

Compound 4, half-maximal inhibitory concentration: 78100 nM
The estimate for compound 4 lay 1.3-fold (0.11 log units) below the measured number, within the range that was stated.
By their numbers in this assay, from the lowest: compounds 3, 4 and 2 (each within the scatter of the next); then compound 1.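

In this assay, the first change shown on an amine nitrogen in a ring, 1,3-benzothiazol-2-yl in place of 1,3-benzoxazol-2-yl, gives a 1.2-fold higher number from compound 3 to compound 4 (0.09 log units; within the scatter) and so leaves the two compounds unranked. At this position, exchanging the ring oxygen for sulfur therefore produces no readable change in this cell assay. Nothing available offers an explanation for this result.

From the compounds shown here alone, it remains open how a smaller group on that nitrogen, such as phenyl or methyl, would read out. Going by these compounds, whether the exchange behaves alike with 4-hydroxyphenyl at the other end of the shared core also remains open.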